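Cyano for Methyl on a Fused Core

A few compounds are considered here, and "the series" means these few. Any claim that something is new, unique, unknown or untested is made for them only; others in the source may bear on it.

Three compounds share a fused two-ring core carrying a substituted phenyl group and a branched amine. Compound 1 `COCc1cc(OC)c(-c2cccc3c(N(CC4CCOCC4)CC4CC4)c(C)nn23)c(OC)c1` gives 50 nM in a functional assay on HEK293 cells for antagonist activity at corticotropin-releasing factor receptor 1 (Homo sapiens), read by fluorescence and cAMP accumulation, with a stated time of 30 min; a higher number here means a weaker inhibitor, a lower number a stronger inhibitor. Compound 3 `CCc1nn2c(-c3c(C)cc(OC)cc3C)cccc2c1N(CC1CC1)CC1CC1` gives 90 nM in this assay, a number that lies within the usual scatter of compound 1. Compound 2 `CCc1nn2c(-c3c(OC)cc(C)cc3OC)cccc2c1N(CC1CCOCC1)CC1CC1` gives 20 nM in this assay, a lower number that falls beyond the scatter, so compound 1 sits between the two others without being clearly separated from compound 3.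

Compound 4 `COCc1cc(OC)c(-c2cccc3c(N(CC4CCOCC4)CC4CC4)c(C#N)nn23)c(OC)c1` is a close relative of compound 1 and has not yet been measured. The single difference is cyano in place of methyl on an aromatic carbon. Among the compounds with values here, no pair among the measured compounds shows this change, so there is no measured step to lean on. A small step is expected, without a clear direction beyond the scatter, leaning slightly toward a higher number. The step of a 1.6-fold higher number from compound 1 to compound 4 (0.20 log units; within the scatter) is thus expected to stay modest. Compound 4 is expected to give about 80 nM in this assay, within a range from 25 nM to 250 nM.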

Compound 4, half-maximal inhibitory concentration in the corticotropin-releasing factor receptor 1 assay: 52 nM
The estimate for compound 4 lay 1.5-fold (0.19 log units) above the measured number, within the range that was stated.
By their numbers in the corticotropin-releasing factor receptor 1 assay, from the lowest: compound 2; then compounds 1, 4 and 3 (each within the scatter of the next).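

In the corticotropin-releasing factor receptor 1 assay, cyano in place of methyl on this aromatic carbon, next to the ring nitrogen, gives a 1.0-fold higher number from compound 1 to compound 4 (0.02 log units; within the scatter), so this position accepts a cyano group, with its hydrogen-bond acceptor, and the two compounds cannot be told apart as inhibitors. The pair does separate elsewhere: in a physicochemical assay for solubility, in phosphate buffer, measured as kinetic solubility (a higher number here means a more soluble compound, a lower number a less soluble compound), compound 1 gives 21000 nM and compound 4 gives 1700 nM. The price of this swap therefore appears in solubility and not in the inhibitor number: the measured solubility of compound 1, 21000 nM, and of compound 4, 1700 nM, a 12-fold lower number (1.09 log units; beyond the scatter)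

From the compounds shown here alone, whether a chlorine atom or a primary amide at this position would match compound 1 in both assays remains open. This is also a single pair, so it cannot say whether cyano would behave the same way alongside the other phenyl and amine groups of compound 2 and compound 3.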